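Halogen for methyl on the aryl of the core

The source may report more compounds than this note shows. Statements on the series, on what has been measured and on what is new or still open speak of the compounds shown alone.

For the measured compounds named here, compound 3 `Cc1ccc(/C=C/C(=O)Nc2nnc(-c3ccc(C)cc3)s2)cc1` gives the lowest number of the three measured so far in a functional assay on A549 cells (Homo sapiens) for antiproliferative activity, read by MTT assay, with a stated time of 48 h (on this read-out lower numbers stand for stronger inhibition and higher numbers for weaker inhibition), at 1.08 ug/mL. Compound 1 `Cc1ccc(-c2nnc(NC(=O)/C=C/c3ccc(C(F)(F)F)cc3)s2)cc1` stands nearest, at 1.61 ug/mL, a gap within the scatter; compound 2 `O=C(/C=C/c1ccccc1)Nc1nnc(-c2ccc(Br)cc2)s1` stands furthest, at 2.18 ug/mL, a gap beyond it. Going by the values given here, the single measured step, a 1.5-fold lower number from compound 1 to compound 3 (0.17 log units; within the scatter), concerns methyl against trifluoromethyl on the cinnamoyl side and falls within the scatter.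

Compound 4 `Cc1ccc(/C=C/C(=O)Nc2nnc(-c3ccc(Cl)cc3)s2)cc1` differs from compound 3 by chloro in place of methyl on an aromatic carbon, on an aromatic carbon of a six-membered aromatic ring of carbon only. Among the compounds with values here, no measured pair shows this change alone; compound 2 carries a halogen on the same ring but also lacks the methyl on the cinnamoyl side, so its value speaks to both changes at once. Within the data shown here, the one measured step was small, and the new change is comparably slight in size, so no step beyond the scatter is expected in this assay.

For compound 4 the expected value in this assay is 1.5 ug/mL, with a range of 0.8 ug/mL to 3 ug/mL, an expected step of a 1.4-fold higher number from compound 3 to compound 4 (0.14 log units; within the scatter).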

Compound 4, half-maximal inhibitory concentration: 1.25 ug/mL
Compound 4: the middle estimate sits 1.2-fold (0.08 log units) above what was measured; measured number inside the range.
By their numbers in this assay, from the lowest: compounds 3, 4, 1 and 2 (each within the scatter of the next, the first and the last beyond it).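

For the compounds shown here, the step gives the first single-change reading at the aryl of the core: in this assay, going from 4-methylphenyl to 4-chlorophenyl gives a 1.2-fold higher number from compound 3 to compound 4 (0.06 log units; within the scatter), so chloro in place of methyl at this position produces no difference that can be told from the scatter. The earlier step at the other aryl, a 1.5-fold lower number from compound 1 to compound 3 (0.17 log units; within the scatter), also lies within the scatter, so neither single change shown so far separates its pair. No measurement at hand offers an explanation for this result.

As far as these compounds go, whether the position stays this flat with a methoxy, an amine or a carboxylic acid in the same place remains open. The bromo of compound 2 comes with a second change at the other aryl, so its own contribution stays unresolved.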